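The compounds below may be only part of what the source reports. "The series", "measured", "known", "first", "only" and "open" are said of these compounds alone.

Values in a functional assay (Homo sapiens) for inhibition (on this read-out lower numbers stand for stronger inhibition and higher numbers for weaker inhibition), so far
compound 1 `COc1cc(/C=C/C(=O)c2ccccc2N(C)C)cc(OC)c1` gives 5700 nM
compound 2 `COc1cc(/C=C/C(=O)c2cccc(N(C)C)c2)cc(OC)c1` gives 5000 nM
compound 3 `COc1cc(/C=C/C(=O)c2ccc(C3CCCCC3)cc2)cc(OC)c1` gives 39000 nM

Compound 3 holds the highest of the three numbers, beyond the scatter from both compound 1 and compound 2, which lie within the scatter of each other. Compound 4 `C=CCOc1ccc(C(=O)/C=C/c2cc(OC)cc(OC)c2)cc1` carries allyloxy in place of cyclohexyl on an aromatic carbon, para to a large group allyloxy in place of cyclohexyl on an aromatic carbon on the shared core. Among the compounds with values here, no measured pair differs in one place only, so no measured step guides the size of this change. A moderate move to a lower number is expected, a 2.8-fold lower number from compound 3 to compound 4 (0.44 log units; beyond the scatter) being the step estimated. For compound 4 the estimate is 14000 nM with 5000 nM to 38000 nM as the expected range.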

Compound 4, half-maximal inhibitory concentration: 25000 nM
Estimate against measurement, compound 4: 1.8-fold (0.25 log units) below, within the range that was stated.
By their numbers in this assay, from the lowest: compounds 2 and 1 (each within the scatter of the next); then compounds 4 and 3 (each within the scatter of the next).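

In this assay, within the data shown here, allyloxy in place of cyclohexyl on an aromatic carbon, para to a large group, gives a 1.6-fold lower number from compound 3 to compound 4 (0.19 log units; within the scatter), a first step at this position. Replacing a six-membered non-aromatic ring of carbon only with an open group carrying a hydrogen-bond acceptor therefore leaves the read-out within the scatter. Nothing at hand bears on why the two groups read alike. Still open, from the compounds shown here alone, is whether an amine, a carboxylic acid or a longer chain at this position would move the number beyond the scatter.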